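Diacetate sulfonamide series: a benzyl replaces the phenylbutyl

A few compounds are considered here, and "the series" means these few. Any claim that something is new, unique, unknown or untested is made for them only; others in the source may bear on it.

Measured so far:
compound 1 `O=S(=O)(/C=C/c1ccc(O)c(O)c1)NCCCCc1ccccc1`: 3.8 10^-6 cm/s
compound 2 `CC(=O)Oc1ccc(/C=C/S(=O)(=O)NCCCCc2ccccc2)cc1OC(C)=O`: "nd(insoluble)" (no result reported)

In an ADME assay for permeability, using PAMPA, with a stated time of 18 h, tested at 25 ug/mL (a higher number here means that the compound crosses the layer faster, a lower number that the compound crosses the layer more slowly), compound 1 gives 3.8 10^-6 cm/s. In this assay compound 2 gives "nd(insoluble)" (no result reported), so no number stands for it and it cannot be placed on the scale. Compound 3 `COc1ccc(CNS(=O)(=O)/C=C/c2ccc(OC(C)=O)c(OC(C)=O)c2)cc1` arises from compound 2 by 4-methoxyphenyl in place of 3-phenylpropyl on a saturated chain carbon bound to a sulfonamide nitrogen. Going by the values given here, with no number for compound 2, no step can be reckoned for this change. Compound 3 is expected to give a readable value in this assay near that of compound 1, roughly 4 10^-6 cm/s, with a range from 1.2 10^-6 cm/s to 12 10^-6 cm/s.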

Compound 3, apparent permeability: 11.6 10^-6 cm/s
Beside the measured number, compound 3's estimate is 2.9-fold (0.46 log units) below it; the range from low to high includes it.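

In this assay, going by these compounds alone, compound 3 gives 11.6 10^-6 cm/s while compound 2 gives "nd(insoluble)" (no result reported) so no step between compound 2 and compound 3 can be read. The compounds shown leave open how replacing 3-phenylpropyl with 4-methoxyphenyl changes the read-out. No evidence here explains the value of compound 3.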